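Capping one hydroxy group of compound 1

The compounds below may be only part of what the source reports. "The series", "measured", "known", "first", "only" and "open" are said of these compounds alone.

In a functional assay on OVCAR-3 cells (Homo sapiens) for cytotoxicity, read by sulforhodamine B assay, with a stated time of 48 h (on this read-out lower numbers stand for stronger inhibition of growth and higher numbers for weaker inhibition of growth), compound 1 (`COc1cc(C(=O)c2ccc(OC)c(O)c2OC)cc(OC)c1O`) gives 363 nM. That is the lower of the two numbers available, and so the stronger growth inhibition: compound 2 (`COc1cc(C(=O)c2ccc3c(c2)oc(=O)n3S(C)(=O)=O)cc(OC)c1OC`) gives 1560 nM, a gap beyond the usual scatter. Compound 3 (`COc1ccc(C(=O)c2cc(OC)c(OC)c(OC)c2)c(OC)c1O`) has not yet been measured. It turns one hydroxy into methoxy, with methyl in place of hydrogen on an oxygen on an aromatic ring. Among the measured compounds shown here, no measured pair shows this change, and compound 2 differs from compound 1 in more than one place, so the data offer no direct guide. A moderate gain in this assay is still expected, though this is a loose judgement. The estimated size is a 3.6-fold lower number from compound 1 to compound 3 (0.56 log units; beyond the scatter), towards a lower number. For compound 3, the expected value is 100 nM, with a likely range from 15 nM to 500 nM.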

Compound 3, concentration for 50% growth inhibition: 22.2 nM
Compound 3: middle estimate off by 4.5-fold (0.65 log units), on the high side; low and high end bracket the measured number.
By their numbers in this assay, from the lowest: compound 3; then compound 1; then compound 2.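

In this assay, putting methyl in place of hydrogen on this one aromatic oxygen, so that hydroxy becomes methoxy, gives a 16-fold lower number from compound 1 to compound 3 (1.21 log units; beyond the scatter). This shows that the free hydroxy at this position is not needed for growth inhibition in this series, and that a single added carbon here can change the result by a large margin. Nothing in the data accounts for the size of this step.

On these data alone, how a longer chain such as ethyl on the same oxygen, or an amine in place of the hydroxy, would compare with methoxy remains open. The contribution of the other hydroxy, which compound 3 keeps, also remains open, as no pair of compounds shown changes that group alone.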